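Removing a chloro group from an inactive pair

The source may hold more compounds than are shown below. What is called first, only, known or untested is meant among the compounds shown, and "the series" means these compounds.

Two measured compounds share one core and differ only in the group on the six-membered aromatic ring of carbon only. Compound 1 `CC1=CSC(O)(c2ccc(C)cc2)c2noc(=O)n21` is one of them, and in a functional assay on A2780 cells (Homo sapiens) for antiproliferative activity, read by MTT assay, with a stated time of 3 days (a higher number here means a weaker inhibitor, a lower number a stronger inhibitor), compound 1 gives only the assay limit > 100000 nM. Compound 2 `CC1=CSC(O)(c2cccc(Cl)c2)c2noc(=O)n21` is the other, and in this assay compound 2 likewise reaches only the limit > 100000 nM. Both sit at the limit of > 100000 nM in this assay, at which 2 of the 2 values shown sit, so no number places compound 2 within the measurable range. Compound 3 `CC1=CSC(O)(c2ccccc2)c2noc(=O)n21` differs from compound 2 by hydrogen in place of chloro on an aromatic carbon. Going by the values given here, with no measured step between these compounds, a change of a step that the limit leaves unreadable from compound 2 to compound 3 is expected, nothing beyond the scatter. Compound 3 is estimated at 150000 nM, between 50000 nM and 500000 nM, most likely again only a limit.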

Compound 3, half-maximal inhibitory concentration: > 100000 nM
Compound 3 was reported as a limit; the forecaster's own chance of this, stated with the estimate: 85%; the middle value lies beyond the limit too.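

No step can be read among compound 1, compound 2 and compound 3, since each is reported only as an assay limit: the limit of > 100000 nM in this assay, at which 3 of the 3 values shown sit.

These compounds leave open whether hydrogen, methyl or chloro on the aromatic ring makes any difference in this assay.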